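The compounds below may be only part of what the source reports. "The series", "measured", "known", "first", "only" and "open" are said of these compounds alone.

Measured so far in a functional assay on MCF7 cells (Homo sapiens) for inhibition, read by sulforhodamine B assay, with a stated time of 48 h; a lower number here means a stronger inhibitor of growth, a higher number a weaker inhibitor of growth:

Compound 1, `COC(=O)c1sc2cc(-c3ccc(F)nc3)cnc2c1N`, gives "not determined" (no result reported).
Compound 2, `COC(=O)c1sc2cc(-c3ccc(C#N)cc3)cnc2c1N`, gives > 75000 nM, which is a limit of this assay rather than a number.
Compound 3, `COC(=O)c1sc2cc(-c3ccccc3N)cnc2c1N`, gives 4200 nM.

Going by the values given here, compound 3 thus stands as the only compound here with a number in this assay; one further entry is a limit of the assay and one has no result. The limit of compound 2 is described by the limit of > 75000 nM in this assay, at which 1 of the 3 values shown sits.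

Compound 4, `COC(=O)c1sc2cc(-c3ccc(N)cc3)cnc2c1N`, has not yet been measured. It differs from compound 3 in one place: 4-aminophenyl in place of 2-aminophenyl on an aromatic carbon. The same group, an aminophenyl ring, is kept, but the amine sits in a different position on that ring.

Among the compounds with values here, no step between measured compounds is known that would show how this change acts, so the expectation rests on compound 3 alone. The step from compound 3 to compound 4 in this assay is expected to be a 2.1-fold higher number from compound 3 to compound 4 (0.33 log units; beyond the scatter), a modest weakening beyond the usual scatter. Compound 4 is therefore expected to give about 9000 nM, within a range of 2000 nM to 40000 nM.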

Compound 4, concentration for 50% growth inhibition: 108000 nM
Estimate against measurement, compound 4: 12-fold (1.08 log units) below; measured number above the stated range.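

In this assay, moving the amine around the same ring, with 4-aminophenyl in place of 2-aminophenyl, gives a 26-fold higher number from compound 3 to compound 4 (1.41 log units; beyond the scatter), a large weakening of growth inhibition. The earlier compounds shown here offered no such comparison; this pair shows that at this position the place of the amine on the ring matters, not only its presence, since the two groups have the same atoms and the same counts of hydrogen-bond donors and acceptors. The step from compound 2 to compound 4 cannot be read because the value of compound 2 is a limit of the assay, not a number: the limit of > 75000 nM in this assay, at which 1 of the 4 values shown sits.

Why the 2-aminophenyl group does better remains unexplained, and whether a hydroxyl or methyl group in place of its amine would keep the activity of compound 3 stays open. Also open, going by these compounds, is whether a plain phenyl ring would sit nearer compound 3 or compound 4.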